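Benzyl ether variation on the shared core

The compounds below may be only part of what the source reports. "The series", "measured", "known", "first", "only" and "open" are said of these compounds alone.

Measured so far in an assay on CHO cells for binding affinity to metabotropic glutamate receptor 2 (Rattus norvegicus); a lower number here means a stronger inhibitor, a higher number a weaker inhibitor:
- compound 1 `CO[C@@H]1C[C@@H]2[C@H]([C@]1(N)C(=O)O)[C@@]2(F)C(=O)O` gives 39.2 nM
- compound 2 `N[C@]1(C(=O)O)[C@H]2[C@@H](C[C@H]1OCc1ccccc1)[C@]2(F)C(=O)O` gives 7.14 nM
- compound 3 `N#Cc1cccc(CO[C@@H]2C[C@@H]3[C@H]([C@]2(N)C(=O)O)[C@@]3(F)C(=O)O)c1` gives 2.94 nM

Compound 3 stands lowest of the three numbers. The nearest measured neighbour is reached by the step of a 2.4-fold lower number from compound 2 to compound 3 (0.39 log units; beyond the scatter) and the furthest by the step of a 13-fold lower number from compound 1 to compound 3 (1.12 log units; beyond the scatter).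

Compound 4 `N[C@]1(C(=O)O)[C@H]2[C@@H](C[C@H]1OCc1ccc(F)c(F)c1)[C@]2(F)C(=O)O` differs from compound 3 in one place: 3,4-difluorophenyl in place of 3-cyanophenyl on a saturated chain carbon bound to an oxygen on a saturated carbon. Among the measured compounds shown here, two measured steps bear on this. The step of a 5.5-fold lower number from compound 1 to compound 2 (0.74 log units; beyond the scatter) shows that placing a phenyl on the chain carbon lowers the number clearly; the step of a 2.4-fold lower number from compound 2 to compound 3 (0.39 log units; beyond the scatter) shows that the cyano on that ring brings a further, modest lowering. For the measured compounds named here, no measured step replaces a cyano by fluorines on the ring, so the size of the present change is not directly covered. Compound 4 keeps the ring that carried the main gain and loses the cyano that carried the smaller one, so its number is expected to lie between those of compound 2 and compound 3, giving in this assay an expected step of a 1.5-fold higher number from compound 3 to compound 4 (0.18 log units; within the scatter) that stays within the scatter. The estimate for compound 4 in this assay is 4.5 nM, with a range of 1.8 nM to 11 nM.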

Compound 4, inhibition constant: 2.27 nM
Estimate against measurement, compound 4: 2.0-fold (0.30 log units) above; the measured number falls inside the stated range.
By their numbers in this assay, from the lowest: compounds 4 and 3 (each within the scatter of the next); then compound 2; then compound 1.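

In this assay, the 3,4-difluorophenyl and 3-cyanophenyl groups on the saturated chain carbon cannot be told apart, with a 1.3-fold lower number from compound 3 to compound 4 (0.11 log units; within the scatter), so a nitrile on the ring is not needed for a number at this level, and an entering group with 0 hydrogen-bond acceptors serves as well. Against the unsubstituted phenyl, the two fluorines give a real gain, with a 3.1-fold lower number from compound 2 to compound 4 (0.50 log units; beyond the scatter). Measured from the hydrogen on that chain carbon, the 3,4-difluorophenyl group gives a 17-fold lower number from compound 1 to compound 4 (1.24 log units; beyond the scatter), on the scale of a 13-fold lower number from compound 1 to compound 3 (1.12 log units; beyond the scatter).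

No supporting data bear on why these two ring groups give such close numbers. From the compounds shown here alone, whether a ring with a single fluorine, a ring with a methoxy group, or an amine or longer chain in place of the 3,4-difluorophenyl holds the number at this level stays open.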